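Hydroxy for methoxy on the benzylated series

This account rests on a few compounds, and the source may have more. Where it says the series, first, only, none or still open, it means among the compounds named here.

Measured in a functional assay on U-937 cells (Homo sapiens) for cytotoxicity, read by resazurin assay, with a stated time of 72 h; a higher number here means a weaker inhibitor, a lower number a stronger inhibitor:
- compound 1 `COc1cc(OC)c(C(=O)/C=C/c2ccccc2)c(OC)c1`: 6700 nM
- compound 2 `C=CCOc1ccccc1Cc1c(OC)cc(OC)c(C(=O)/C=C/c2ccccc2)c1OC`: 7500 nM
- compound 3 `COc1cc(OC)c(C(=O)/C=C/c2ccccc2)c(OC)c1Cc1ccccc1O`: 4200 nM

The three values sit close together. Compound 3, at 4200 nM, does not separate from the other two: a 1.6-fold lower number from compound 1 to compound 3 (0.20 log units; within the scatter) and a 1.8-fold lower number from compound 2 to compound 3 (0.25 log units; within the scatter) both stay within the scatter. Adding a substituted benzyl to the core of compound 1 also left this assay essentially unmoved, with a 1.1-fold higher number from compound 1 to compound 2 (0.05 log units; within the scatter).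

Compound 4 `COc1cc(OC)c(C(=O)/C=C/c2ccccc2)c(O)c1Cc1ccccc1O` departs from compound 3 by hydrogen in place of methyl on an oxygen on an aromatic ring, that is, methoxy to hydroxy.

The nearest measured precedent is the exchange of allyl for hydrogen on an oxygen, at a different oxygen and with a different group leaving: a 1.8-fold lower number from compound 2 to compound 3 (0.25 log units; within the scatter). This step is small and within the scatter, so it supports only a weak lean toward a lower number. For the measured compounds named here, no measured compound shows this methoxy to hydroxy change directly, so a larger shift cannot be excluded.

The estimated change is a 1.4-fold lower number from compound 3 to compound 4 (0.15 log units; within the scatter), which is not expected to clear the scatter. For compound 4 the expected value is 3000 nM, with an estimated range of 1200 nM to 7500 nM.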

Compound 4, half-maximal inhibitory concentration: 6800 nM
Compound 4: middle estimate off by 2.3-fold (0.36 log units), on the low side; the range from low to high includes it.
By their numbers in this assay, from the lowest: compounds 3, 1, 4 and 2 (each within the scatter of the next).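

In this assay, for the compounds shown here, the exchange of methoxy for hydroxy on the core gives a 1.6-fold higher number from compound 3 to compound 4 (0.21 log units; within the scatter), the first direct reading of this change. The earlier steps shown here altered only the benzyl group or the allyl on its oxygen, whereas this step shows that, with the 2-hydroxybenzyl group in place, a methyl can leave this oxygen on the aromatic ring and a hydrogen enter without compound 4 separating from compound 3. The data in hand offer no measured basis for interpreting this small step.

Still open, as far as these compounds go, is whether the same methoxy to hydroxy exchange would read alike on the core of compound 1, without the 2-hydroxybenzyl group. Also open, from the compounds shown here alone, is whether a longer chain such as n-butyl on this oxygen, or an amine in place of the hydroxy, would move the number beyond the scatter at this position.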